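This account rests on a few compounds, and the source may have more. Where it says the series, first, only, none or still open, it means among the compounds named here.

Measured compounds:
Compound 1 `Cn1nc(Cc2nnc(SCC(=O)Nc3ccc(Cl)cc3Cl)n2CCC=O)c2ccccc2c1=O` gives 4200 nM in an assay on NK92 cells for inhibition of interleukin-15 (Homo sapiens), read by AlphaScreen, with stated times of 30 min and 1 h; a higher number here means a weaker inhibitor, a lower number a stronger inhibitor.
Compound 2 `Cn1nc(Cc2nnc(SCC(=O)Nc3ccc(Cl)cc3Cl)n2CCCO)c2ccccc2c1=O` gives > 30000 nM in this assay, which is a limit of the assay and not a number.
Compound 3 `Cn1c(Cc2nn(CCC=O)c(=O)c3ccccc23)nnc1SCC(=O)Nc1ccc(Cl)cc1Cl` gives 20000 nM in this assay.

Compound 3 has the same atoms as compound 1, joined differently; the difference between the two cores is not broken down here. Compound 3 stands at the weaker end of the two numbers, beyond the scatter from compound 1. Among the measured compounds shown here, the one change measured so far is hydroxymethyl in place of formyl on a saturated chain carbon, two bonds along the chain from an aromatic nitrogen, and it gave an at least 7.1-fold higher number from compound 1 to compound 2 (0.85 log units; beyond the scatter), with compound 2 resting at the limit of > 30000 nM in this assay, at which 1 of the 3 values shown sits.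

Compound 4 `Cn1c(Cc2nn(CCCO)c(=O)c3ccccc23)nnc1SCC(=O)Nc1ccc(Cl)cc1Cl` has not yet been measured in this assay. It differs from compound 3 by hydroxymethyl in place of formyl on a saturated chain carbon, two bonds along the chain from an aromatic nitrogen, the same change that turned compound 1 into compound 2. Since compound 3 already gives 20000 nM, compound 4 is expected to weaken at least as far, a 5.0-fold higher number from compound 3 to compound 4 (0.70 log units; beyond the scatter). Compound 4 may well give only a limit of the assay rather than a number. The estimate for compound 4 in this assay is 100000 nM, between 30000 nM and 400000 nM.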

Compound 4, half-maximal inhibitory concentration: 30000 nM
Beside the measured number, compound 4's estimate is 3.3-fold (0.52 log units) above it; the measured number falls inside the stated range.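

On the core of compound 3, the change of formyl to hydroxymethyl gave a 1.5-fold higher number from compound 3 to compound 4 (0.18 log units; within the scatter) in this assay, so on that core its effect cannot be told from the scatter. The change therefore did not carry over at the same size from the core of compound 1: the same change on two cores in this assay, an at least 7.1-fold higher number (0.85 log units; beyond the scatter) from compound 1 to compound 2 and a 1.5-fold higher number (0.18 log units; within the scatter) from compound 3 to compound 4, at least 4.7-fold (0.67 log units) apart, beyond the scatter of two such steps. Among the compounds shown here, compound 2 gives > 30000 nM, which is a limit of the assay and not a number, so the comparison shows only that the two steps differ, not the full size of the first step or why the two cores respond differently.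

The compounds shown leave open how the two cores would compare with any other end group on the chain, such as an amine or a carboxylic acid in place of the formyl or hydroxymethyl. They also leave open whether a longer chain than 2-formylethyl or 3-hydroxypropyl would keep the difference between the two cores.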